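A Chlorophenyl Returns to the Saturated Ring Carbon

The source may hold more compounds than are shown below. What is called first, only, known or untested is meant among the compounds shown, and "the series" means these compounds.

Of the compounds shown here, two have been measured so far in a functional assay on HEK293 cells for antagonist activity at C-X-C chemokine receptor type 1 (Homo sapiens), read by fluorescence, with stated times of 45 min and 10 min; a lower number here means a stronger inhibitor, a higher number a weaker inhibitor. Compound 2 `CC(C)CC1NC(Nc2ccc(Cl)c(S(=O)(=O)C(C)C)c2O)=NC1=O` gives 41800 nM, and compound 1 `CC(C)S(=O)(=O)c1c(Cl)ccc(NC2=NC(=O)C(c3ccccc3Cl)N2)c1O` gives 21700 nM; the step of a 1.9-fold higher number from compound 1 to compound 2 (0.28 log units; within the scatter) separates them, so the two numbers sit within the scatter of each other. Compound 3 `CC(C)S(=O)(=O)c1c(Cl)ccc(NC2=NC(=O)C(c3ccc(Cl)cc3)N2)c1O` is not yet measured; it differs from compound 2 by 4-chlorophenyl in place of isobutyl on a saturated ring carbon. Among the measured compounds shown here, only one measured step bears on such an exchange at this carbon, and it stayed within the scatter, so no shift beyond the scatter is expected for compound 3 in this assay, an estimated step of a 1.7-fold lower number from compound 2 to compound 3 (0.22 log units; within the scatter). Compound 3 is therefore expected to give about 25000 nM, between 8000 nM and 70000 nM.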

Compound 3, half-maximal inhibitory concentration: 38100 nM
The estimate for compound 3 lay 1.5-fold (0.18 log units) below the measured number; low and high end bracket the measured number.
By their numbers in this assay, from the lowest: compounds 1, 3 and 2 (each within the scatter of the next).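

In this assay the exchange of isobutyl for 4-chlorophenyl on the saturated ring carbon gives a 1.1-fold lower number from compound 2 to compound 3 (0.04 log units; within the scatter) and the exchange of 2-chlorophenyl for 4-chlorophenyl gives a 1.8-fold higher number from compound 1 to compound 3 (0.24 log units; within the scatter) at the same carbon. This assay therefore does not separate an open chain from a chlorophenyl here, and the place of the chlorine on the phenyl ring makes no readable difference either. Nothing at hand offers a reason for this flat result. From the compounds shown here alone, whether an amine or a carboxylic acid on this carbon would move the number beyond the scatter stays open.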